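Swapping the Aryl Group on a Shared Urea Core

The source may report more compounds than this note shows. Statements on the series, on what has been measured and on what is new or still open speak of the compounds shown alone.

Compound 1, `COc1cc(NC(=O)Nc2cc(Nc3ccc(C)c(F)c3)ncn2)cc(OC)c1`: 72%
Compound 2, `COc1cc(Nc2cc(NC(=O)Nc3c(Cl)cccc3Cl)ncn2)cc(C(F)(F)F)c1`: 57.7%

Of the compounds shown here, two have been measured in a functional assay on HCC827 cells (Homo sapiens) for inhibition, read by MTT assay, with a stated time of 48 h, tested at 10 uM; on this read-out higher numbers stand for more inhibition at the one concentration tested (going by the name of the read-out) and lower numbers for less inhibition. Compound 1 gives 72%, the highest of the two numbers. Compound 2 gives 57.7%, which lies below compound 1 by more than the usual scatter. Compound 3, `COc1cc(NC(=O)Nc2cc(Nc3ccc(OC)c(C)c3)ncn2)cc(OC)c1`, has not yet been measured. It differs from compound 1 in one place: 4-methoxy-3-methylphenyl in place of 3-fluoro-4-methylphenyl on a nitrogen on an aromatic ring. Within the data shown here, no step between measured compounds is known. The step from compound 1 to compound 3 is expected to be a number 7 percentage points lower from compound 1 to compound 3 (within the scatter), no larger than the scatter. Compound 3 is expected to give about 65%, probably between 40% and 85%.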

Compound 3, a percentage reported as inhibition, at one concentration (the size of the read-out at that concentration, not a potency): 48.3%
Beside the measured number, compound 3's estimate is 16.7 percentage points above it; low and high end bracket the measured number.
By their numbers in this assay, from the lowest: compounds 3 and 2 (each within the scatter of the next); then compound 1.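

The swap from 3-fluoro-4-methylphenyl to 4-methoxy-3-methylphenyl on this nitrogen gives, in this assay, a number 23.7 percentage points lower from compound 1 to compound 3 (beyond the scatter). Among these compounds, this is the first comparison in which only one place changes, and it shows that the read-out responds to the choice of aryl group here. Nothing available explains the drop.

Going by these compounds, both the fluoro and the methoxy substituent differ in name and placement, so the share of each in the step stays open. On these data alone, how an amine or a carboxylic acid on this phenyl group would read also remains open.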